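Hydroxy for Chloro in a Weakly Cytotoxic Series

The source may report more compounds than this note shows. Statements on the series, on what has been measured and on what is new or still open speak of the compounds shown alone.

Compound 1, `COc1ccc(Nc2nc(-c3cccc(F)c3)nc3ccc(F)cc23)cc1`: in a functional assay on HL-60 cells (Homo sapiens) for cytotoxicity, read by MTT assay, with a stated time of 48 h (on this read-out higher numbers stand for weaker inhibition and lower numbers for stronger inhibition), compound 1 gives 38600 nM.
Compound 2, `Fc1cccc(-c2nc(Nc3ccccc3Cl)c3cc(F)ccc3n2)c1`: in this assay compound 2 reaches only a limit of the assay, > 50000 nM.

Compound 2 therefore stands at the edge of what the assay can report: its entry is a limit, not a number, as one of the two measured compounds sits at the limit of > 50000 nM in this assay, at which 1 of the 2 values shown sits. Among the compounds with values here, the single measured step, an at least 1.2-fold higher number from compound 1 to compound 2 (0.11 log units; that floor lies within the scatter), is itself small and runs up to that limit, so no measured difference between the two compounds is secured beyond the scatter.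

Compound 3, `Oc1ccccc1Nc1nc(-c2cccc(F)c2)nc2ccc(F)cc12`, differs from compound 2 by hydroxy in place of chloro on an aromatic carbon. Within the data shown here, no measured step involves a hydroxy group or any other change at this position, so nothing among the measured steps bears directly on this swap. Among the measured compounds shown here, the only guidance is that the closest measured compounds give weak inhibition or a limit. Compound 3 is therefore expected to stay near the limit, with an expected step that the limit leaves unreadable from compound 2 to compound 3. The estimate for compound 3 in this assay is 60000 nM, expected to lie between 20000 nM and 200000 nM.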

Compound 3, half-maximal inhibitory concentration: 44400 nM
Beside the measured number, compound 3's estimate is 1.4-fold (0.13 log units) above it, and the stated range covers the measured number.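

In this assay compound 3 gives 44400 nM, so with 2-hydroxyphenyl on the nitrogen the assay returns an actual number, and this position now has a readable value. Compound 2, which carries chloro at the same place, has > 50000 nM, and this is a limit of the assay, not a number. Putting hydroxy in place of chloro gives an at least 1.1-fold lower number from compound 2 to compound 3 (0.05 log units; that floor lies within the scatter), while moving from 4-methoxyphenyl to 2-hydroxyphenyl on the nitrogen gives a 1.2-fold higher number from compound 1 to compound 3 (0.06 log units; within the scatter), so neither step secures a difference and hydroxy at this place, ortho to a large group, leaves inhibition weak.

Whether a different group at this place, such as an amine, a carboxylic acid or a longer chain, would give a clearly lower number stays open, as all three compounds shown remain in the same weak range or at its limit. The full size of the step from chloro to hydroxy also stays open, as compound 2 has no exact value: the limit of > 50000 nM in this assay, at which 1 of the 3 values shown sits.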